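The compounds below may be only part of what the source reports. "The series", "measured", "known", "first", "only" and "open" are said of these compounds alone.

Measured in an ADME assay on L6 cells (Rattus norvegicus) for cytotoxicity, read by resazurin assay, with a stated time of 72 h; a higher number here means a weaker inhibitor, a lower number a stronger inhibitor:
- compound 1 `OC(c1ccc(Cl)cc1)(c1cccnc1)c1nccs1`: > 100000 nM
- compound 2 `OC(c1ccc(Cl)cc1)(c1cccnc1)c1cncs1`: > 100000 nM
- compound 3 `Nc1ncc(C(O)(c2ccc(Cl)cc2)c2cccnc2)s1`: 56000 nM

The entry for compound 1 is a limit and not a number. The entry for compound 2 is a limit too. Within the data shown here, compound 3, at 56000 nM, therefore holds the only true number in the set.

Compound 4 `OC(c1ccc(Cl)cc1)(c1cccnc1)c1cnc(Cl)s1` carries chloro in place of amino on an aromatic carbon.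

The closest measured change is an at least 1.7-fold lower number from compound 2 to compound 3 (0.25 log units; that floor lies within the scatter), which puts amino in place of hydrogen. The step of an at least 1.7-fold lower number from compound 1 to compound 3 (0.25 log units; that floor lies within the scatter) is of the same size, while a step that the two limits leave unreadable from compound 1 to compound 2 gives nothing to read. Among the measured compounds shown here, no measured step involves chloro, so no shift beyond the scatter is expected in this assay. The expected change is a 1.3-fold higher number from compound 3 to compound 4 (0.10 log units; within the scatter). For compound 4 the estimated value is 70000 nM, with an expected range from 30000 nM to 150000 nM.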

Compound 4, half-maximal inhibitory concentration: > 100000 nM
Compound 4: a limit, no number; the forecaster's own chance of this, stated with the estimate: 35%; middle value at least 1.4-fold (0.15 log units) away from the limit.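

In this assay compound 4 gives > 100000 nM, which is a limit and not a number. Chloro in place of amino on this aromatic carbon gives an at least 1.7-fold higher number from compound 3 to compound 4 (0.25 log units; that floor lies within the scatter), so amino remains the only group here with a true number, though that floor does not clear the scatter. The steps from compound 1 and from compound 2 to compound 4 cannot be read, as all three share one limit: the limit of > 100000 nM in this assay, at which 3 of the 4 values shown sit.

On these data alone, how far compound 1, compound 2 and compound 4 lie past that limit stays open. So does whether a methylamino or a methyl group on this carbon would give a true number in this assay.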